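The source may hold more compounds than are shown below. What is called first, only, known or untested is meant among the compounds shown, and "the series" means these compounds.

Of the compounds shown here, three sharing one core have been measured in a functional assay on HT-29 cells (Homo sapiens) for antiproliferative activity, with a stated time of 48 h; a lower number here means a stronger inhibitor, a higher number a weaker inhibitor. Compound 1 `CC(C)(C)c1ccc(NC(=O)NCCCCl)cc1` gives 28000 nM. Compound 2 `CCCCCc1cccc(NC(=O)NCCCCl)c1` gives 28000 nM. Compound 3 `CCCCC(O)c1cccc(NC(=O)NCCCCl)c1` gives 19000 nM, the lowest of the three numbers, though its distance to compound 1 and to compound 2 is within the scatter, so no order among the three can be read from them. For the measured compounds named here, the single step measured on the side chain, a 1.5-fold lower number from compound 2 to compound 3 (0.17 log units; within the scatter), likewise stays within the scatter.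

Compound 4 `CCCCC(OC)c1cccc(NC(=O)NCCCCl)c1` differs from compound 3 by methyl in place of hydrogen on an oxygen on a saturated carbon. Going by the values given here, no measured pair shows this change directly. The only step that touches the same position is the one from compound 2 to compound 3, where introducing the hydroxy group left this assay essentially unchanged; nothing shown indicates that capping that oxygen with a methyl group would move the number further. Compound 4 is therefore expected to sit close to compound 3. The step of no change at the digits printed from compound 3 to compound 4 (within the scatter) is expected to remain within the scatter. The estimate for compound 4 in this assay is 19000 nM, with a range from 8000 nM to 45000 nM.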

Compound 4, half-maximal inhibitory concentration: 56000 nM
For compound 4 the middle estimate is 2.9-fold (0.47 log units) below the measured one, outside the stated range (above it).
By their numbers in this assay, from the lowest: compounds 3, 1, 2 and 4 (each within the scatter of the next, the first and the last beyond it).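

In this assay, the oxygen on this saturated carbon proves to be a place where a change can be read: hydroxy to methoxy gives a 2.9-fold higher number from compound 3 to compound 4 (0.47 log units; beyond the scatter), a modest step, but the first in this series to lie beyond the scatter. The methoxy group in place of hydrogen on the saturated chain carbon gives a 2.0-fold higher number from compound 2 to compound 4 (0.30 log units; within the scatter), so the 1-methoxypentyl and pentyl groups cannot be told apart here, and the effect of the methyl group can be read only against the 1-hydroxypentyl group. Nothing available bears on why capping this oxygen moves the number.

The compounds shown leave open whether this step belongs to the methyl group alone or would also appear with an ethyl group or an acetyl group on the same oxygen. They also leave open whether an amine or a ketone on that saturated carbon would fall nearer the 1-hydroxypentyl or the 1-methoxypentyl value, and whether hydroxy to methoxy would give a similar step on a longer chain.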